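Bromo to Chloro: From Compound 1 to Compound 3

A few compounds are considered here, and "the series" means these few. Any claim that something is new, unique, unknown or untested is made for them only; others in the source may bear on it.

compound 1 `COC(=O)c1ccc(NCc2cncn2Cc2cccc(Br)c2)cc1-c1ccccc1` — > 10000 nM
compound 2 `c1ccc(-c2ccc(Cn3cncc3CNc3ccc(-c4cncs4)c(-c4ccccc4)c3)cc2)cc1` — > 1000 nM

Of the compounds shown here, two have been tested in a toxicity assay on NIH3T3 cells (Mus musculus) for cytotoxicity, read by resazurin assay; a lower number here means that less compound is needed, a higher number that more compound is needed for the effect. For compound 1 the result is a limit of the assay, > 10000 nM, so compound 1 stands only at that limit and not at a number (the limit of > 10000 nM in this assay, at which 1 of the 2 values shown sits). Compound 2 also gives only a limit, > 1000 nM (the limit of > 1000 nM in this assay, at which 1 of the 2 values shown sits). Compound 3 `COC(=O)c1ccc(NCc2cncn2Cc2cccc(Cl)c2)cc1-c1ccccc1` is compound 1 with chloro in place of bromo on an aromatic carbon. For the measured compounds named here, no measured pair shows what such a change does. The step that the limit leaves unreadable from compound 1 to compound 3 is expected to be none beyond the scatter. Compound 3 is therefore estimated at 15000 nM, within 5000 nM to 50000 nM, and a limit is again the likely report.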

Compound 3, half-maximal effective concentration: > 10000 nM
Compound 3: no number, only a limit; the forecaster's own chance of this, stated with the estimate: 80%; the middle value does not contradict the limit.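

In this assay compound 3 gives > 10000 nM, which is a limit. For the compounds shown here, compound 1 also stands only at a limit, so no step between compound 1 and compound 3 can be read. The compounds shown leave open what actual number any of them would reach in this assay.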